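The source may report more compounds than this note shows. Statements on the series, on what has been measured and on what is new or still open speak of the compounds shown alone.

Measured compounds:
- compound 1 `Cc1ccc(/C=N/NC(=O)CSc2nnnn2C)cc1`, 3160000 nM
- compound 2 `Cn1nnnc1SCC(=O)N/N=C/c1ccc(Cl)cc1`, 2100000 nM
- compound 3 `Cn1nnnc1SCC(=O)N/N=C/c1ccc(Br)cc1`, 10000000 nM

In an ADME assay on NIH3T3 cells (Mus musculus) for cytotoxicity, read by XTT assay, with a stated time of 24 h (a higher number here means a weaker inhibitor, a lower number a stronger inhibitor), compound 3 gives the highest of the three numbers; its nearest neighbour is compound 1 and its furthest is compound 2, with a 3.2-fold higher number from compound 1 to compound 3 (0.50 log units; beyond the scatter) and a 4.8-fold higher number from compound 2 to compound 3 (0.68 log units; beyond the scatter) both reaching beyond the scatter, while a 1.5-fold lower number from compound 1 to compound 2 (0.18 log units; within the scatter) stays within it. Compound 4 `Cn1nnnc1SCC(=O)N/N=C/c1ccc(O)cc1` is the unmeasured analogue. The change from compound 3 to compound 4 is hydroxy in place of bromo on an aromatic carbon, on an aromatic carbon of a six-membered aromatic ring of carbon only, para to a large group.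

For the measured compounds named here, two measured steps bear on this change, since both end at compound 3 with bromo entering that position: a 3.2-fold higher number from compound 1 to compound 3 (0.50 log units; beyond the scatter) and a 4.8-fold higher number from compound 2 to compound 3 (0.68 log units; beyond the scatter). Both are modest rises on replacing a methyl or a chloro by bromo. Going by the values given here, no measured step brings in a hydroxy, so the direction of the present step rests only on the observation that the other substituents at this position gave lower numbers than bromo. A modest fall in this assay is therefore expected, roughly undoing the rise seen with bromo, though a flat result within the scatter cannot be excluded. For compound 4 the estimated value is 4000000 nM, with a range from 1500000 nM to 10000000 nM, which corresponds to an expected step of a 2.5-fold lower number from compound 3 to compound 4 (0.40 log units; beyond the scatter).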

Compound 4, half-maximal inhibitory concentration: 632000 nM
Compound 4: the middle estimate sits 6.3-fold (0.80 log units) above what was measured; measured number outside the range, below it.
By their numbers in this assay, from the lowest: compound 4; then compounds 2 and 1 (each within the scatter of the next); then compound 3.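

In this assay, for the compounds shown here, this position proves far more responsive than the methyl, chloro and bromo compounds indicated: hydroxy in place of bromo gives a 16-fold lower number from compound 3 to compound 4 (1.20 log units; beyond the scatter) and so exceeds every step among the earlier compounds. The shift is not confined to the comparison with bromo, since a 3.3-fold lower number from compound 2 to compound 4 (0.52 log units; beyond the scatter) and a 5.0-fold lower number from compound 1 to compound 4 (0.70 log units; beyond the scatter) also lie beyond the scatter and leave compound 4 with the lowest number of the four. Nothing among the data shown explains why hydroxy stands apart from the other three substituents, so only the size of the change can be stated and not its origin.

The compounds shown leave open whether this low number is particular to hydroxy or would also appear with an amine, a methoxy group or a carboxylic acid on the same aromatic carbon. They also leave open whether the order seen among these four substituents would hold if the shared core were altered elsewhere, for example if the methyl on the core gave way to a longer chain.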